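Ring Exchange on the Thioether Terminus of Compound 3

The source may report more compounds than this note shows. Statements on the series, on what has been measured and on what is new or still open speak of the compounds shown alone.

Compound 1, `CC(C)[C@H](NC(=O)COc1cccc2ccccc12)C(=O)N[C@@H](CC(=O)O)C(=O)COc1cc(C(F)(F)F)n(C)n1`, gives 46000 nM in a functional assay on Jurkat cells (Homo sapiens) for inhibition; on this read-out higher numbers stand for weaker inhibition and lower numbers for stronger inhibition.
Compound 2, `COC(=O)c1cc(OCC(=O)[C@H](CC(=O)O)NC(=O)[C@@H](NC(=O)COc2cccc3ccccc23)C(C)C)no1`, gives 71000 nM in this assay.
Compound 3, `CC(C)[C@H](NC(=O)COc1cccc2ccccc12)C(=O)N[C@@H](CC(=O)O)C(=O)CSc1nccn1C`, gives only a limit of the assay in this assay, namely > 200000 nM.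

Compound 3 thus stands at the upper edge of what was measured, at the limit of > 200000 nM in this assay, at which 1 of the 3 values shown sits. The two steps that lead to it both go beyond the scatter: an at least 4.3-fold higher number from compound 1 to compound 3 (0.63 log units; beyond the scatter), and an at least 2.8-fold higher number from compound 2 to compound 3 (0.44 log units; beyond the scatter). Between the two oxygen-linked rings the step is small: a 1.5-fold higher number from compound 1 to compound 2 (0.19 log units; within the scatter).

Compound 4, `CC(C)[C@H](NC(=O)COc1cccc2ccccc12)C(=O)N[C@@H](CC(=O)O)C(=O)CSc1nc(-c2ccccc2)cs1`, keeps the sulfur-linked arrangement of compound 3 and carries 4-phenyl-1,3-thiazol-2-yl in place of 1-methyl-1H-imidazol-2-yl on a sulfur. Within the data shown here, no measured step alters the ring on the sulfur while leaving the sulfur in place; the two steps that reach compound 3 exchange the linking atom and the ring at once, so they cannot be split to isolate the effect of the ring alone. For this assay the expectation is therefore that compound 4 stays near the limit, with a real chance of a number emerging only if the larger ring lifts inhibition. Compound 4 is estimated at 150000 nM, expected between 30000 nM and 500000 nM. The step this estimate means from compound 3 is expected to read an at least 1.3-fold lower number from compound 3 to compound 4 (0.12 log units; that floor lies within the scatter).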

Compound 4, half-maximal inhibitory concentration: > 200000 nM
Compound 4 gave a limit, no number; the forecaster's own chance of this, stated with the estimate: 55%; at least 1.3-fold (0.12 log units) between middle value and limit.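

In this assay compound 4 gives > 200000 nM, a limit of the assay and not a number, and compound 3 now shares that limit: the limit of > 200000 nM in this assay, at which 2 of the 4 values shown sit.

The step between these two sulfur-linked compounds cannot be read, so nothing can be said about whether 4-phenyl-1,3-thiazol-2-yl is better or worse than 1-methyl-1H-imidazol-2-yl on the sulfur. What compound 4 adds is that a second, larger ring on the sulfur also gives no number, while the oxygen-linked compounds stay apart from it, with an at least 4.3-fold higher number from compound 1 to compound 4 (0.63 log units; beyond the scatter) and an at least 2.8-fold higher number from compound 2 to compound 4 (0.44 log units; beyond the scatter); compound 3 alone could not show that this separation holds for more than one ring.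

From the compounds shown here alone, both of these steps still exchange the linking atom and the ring at once, so it remains open whether the sulfur or the rings on it account for the separation. A 4-phenyl-1,3-thiazol-2-yl on an oxygen would separate the two, and a carboxylic acid or an amine on the phenyl ring of compound 4 would test whether any sulfur-linked compound in this series can give a number.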